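A few compounds are considered here, and "the series" means these few. Any claim that something is new, unique, unknown or untested is made for them only; others in the source may bear on it.

Compound 1 `COC1c2ccc(C#Cc3cc(Cl)ccc3OCC(=O)O)cc2S(=O)(=O)C1(C)C`: 21 nM
Compound 2 `CC1(O)c2ccc(C#Cc3cc(Cl)ccc3OCC(=O)O)cc2S(=O)(=O)C1(C)C`: 28 nM

Of the compounds shown here, two have been measured in an assay on CHO cells for displacement of a labelled ligand from prostaglandin D2 receptor 2 (Homo sapiens), read by scintillation counting; on this read-out lower numbers stand for stronger inhibition and higher numbers for weaker inhibition. Compound 2 gives 28 nM, and its nearest neighbour, compound 1, gives 21 nM, a gap that lies within the usual scatter of this assay, so the two numbers read as alike. The next compound, compound 3 `COC1(C)c2ccc(C#Cc3cc(Cl)ccc3OCC(=O)O)cc2S(=O)(=O)C1(C)C`, differs from compound 2 only by methyl in place of hydrogen on an oxygen on a saturated carbon. For the measured compounds named here, no two measured compounds differ in just one place, so no measured step guides this change. Because compound 1 already carries the methoxy and gives 21 nM, the step of a 1.1-fold lower number from compound 2 to compound 3 (0.05 log units; within the scatter) is expected to stay within the scatter, in no clear direction. Compound 3 is therefore estimated at 25 nM, with a likely range from 10 nM to 65 nM.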

Compound 3, inhibition constant: 25 nM
Compound 3: middle estimate and measured number agree at the digits printed, and the stated range covers the measured number.
By their numbers in this assay, from the lowest: compounds 1, 3 and 2 (each within the scatter of the next).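

The step of a 1.1-fold lower number from compound 2 to compound 3 (0.05 log units; within the scatter) swaps hydroxy for methoxy, and it shows that the hydrogen on that oxygen is not needed to keep the number at this level. The step of a 1.2-fold higher number from compound 1 to compound 3 (0.08 log units; within the scatter) puts a methyl in place of hydrogen on a saturated ring carbon, and it shows that this carbon can carry a methyl and a methoxy together without moving the number beyond the scatter. No evidence is at hand on why these numbers stay alike.

From the compounds shown here alone, whether a larger group on this carbon, such as an ethoxy or an amine, would keep the number stays open.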